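Aryl exchange from compound 2 to compound 3

This account rests on a few compounds, and the source may have more. Where it says the series, first, only, none or still open, it means among the compounds named here.

Measured in a functional assay on MCF-A cells (Homo sapiens) for cytotoxicity (on this read-out lower numbers stand for stronger inhibition of growth and higher numbers for weaker inhibition of growth), so far
- compound 1 (`COc1ccc(C2=C(c3ccc(SC)cc3)CC3CCCN3C2=O)cc1OC(=O)C1CCCN1C(=O)OC(C)(C)C`) gives 4000 nM
- compound 2 (`CSc1ccc(C2=C(c3ccc(F)c(F)c3)C(=O)N3CCCC3C2)cc1`) gives 800 nM

Of these two numbers, compound 2 holds the lower (800 nM), and compound 1 stands higher by a margin beyond the scatter. Compound 3 (`COc1ccc(C2=C(c3ccc(SC)cc3)CC3CCCN3C2=O)cc1`) awaits measurement. It carries 4-methoxyphenyl in place of 3,4-difluorophenyl on a double-bonded ring carbon of compound 2 (4-methoxyphenyl in place of 3,4-difluorophenyl on a double-bonded ring carbon), while the 4-(methylsulfanyl)phenyl group stays. Among the measured compounds shown here, no measured pair isolates this exchange, so the expectation rests only on compound 2 (800 nM) and the structural change. In this assay the expected step is small, toward a lower number, and probably not beyond the scatter. The estimated step is a 1.6-fold lower number from compound 2 to compound 3 (0.20 log units; within the scatter) and carries wide uncertainty. For the measured compounds named here, with only two values at hand, the range is kept broad and reaches to either side of compound 2 (800 nM). For compound 3 the expected value is 500 nM (estimated range 100 nM to 2500 nM).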

Compound 3, concentration for 50% growth inhibition: 5000 nM
Estimate against measurement, compound 3: 10-fold (1.00 log units) below; measured number outside the range, above it.
By their numbers in this assay, from the lowest: compound 2; then compounds 1 and 3 (each within the scatter of the next).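

In this assay, among the compounds shown here, 4-methoxyphenyl in place of 3,4-difluorophenyl on the double-bonded ring carbon, with the 4-(methylsulfanyl)phenyl group kept, gives a 6.3-fold higher number from compound 2 to compound 3 (0.80 log units; beyond the scatter), the only single-place step so far. This position therefore responds to the identity of its aryl group: both groups have 8 heavy atoms and one six-membered aromatic ring of carbon only, yet they differ beyond the scatter, with 3,4-difluorophenyl on the side of stronger inhibition of growth. No measurement in hand bears on the reason for this step.

The exchange removes the two fluorines and adds the methoxy group in a single move, so the compounds shown do not separate the contribution of either change. Also open, from the compounds shown here alone, is how this position would respond to plain phenyl, a phenyl carrying a single fluorine, or a phenyl carrying a dimethylamino group, and whether the step would keep its size with another group in place of 4-(methylsulfanyl)phenyl.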